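A few compounds are considered here, and "the series" means these few. Any claim that something is new, unique, unknown or untested is made for them only; others in the source may bear on it.

In an ADME assay on microsomes from liver (Homo sapiens) for metabolic stability, read by LC-MS, using NADPH, with stated times of 5 min and 30 min, tested at 1 uM (a higher number here means faster removal of the compound, a lower number slower removal), compound 1 (`Cc1nc(CN(C)C)ccc1-c1cnc(NCc2c(F)ccc3c2CCO3)c2cn[nH]c(=O)c12`) gives 13 mL.min-1.g-1 and compound 2 (`CN(c1ccccc1)c1cnc(NCc2c(F)ccc3c2CCO3)n2cnnc12`) gives 55 mL.min-1.g-1 as the higher of the two numbers, a gap beyond the usual scatter. Compound 3 (`C[C@H]1CC(=O)N(c2cnc(NCc3c(F)ccc4c3CCO4)n3cnnc23)C1`) keeps the core of compound 2 but carries 4-methyl-2-oxopyrrolidin-1-yl in place of methyl(phenyl)amino on an aromatic carbon. Among the compounds with values here, no measured pair shows this change alone, which leaves the forecast loose. The expected step (a 2.8-fold lower number from compound 2 to compound 3 (0.44 log units; beyond the scatter)) is a moderate fall, beyond the scatter. Compound 3 is estimated at 20 mL.min-1.g-1 with an expected range from 8 mL.min-1.g-1 to 50 mL.min-1.g-1.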

Compound 3, intrinsic clearance in microsomes: < 3 mL.min-1.g-1
Compound 3: no number, only a limit (the forecaster's own chance of this, stated with the estimate: 3%); middle value at least 6.6-fold (0.82 log units) from the limit.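

At this aromatic carbon of the shared core, a single change of group is enough for a large move: 4-methyl-2-oxopyrrolidin-1-yl in place of methyl(phenyl)amino gives an at least 18-fold lower number from compound 2 to compound 3 (1.26 log units; beyond the scatter) in this assay. Compound 1 and compound 2 differ in more than one place and could not show this. Compound 3 sits at a limit, not at a number, so the step gives only a minimum size: the limit of < 3 mL.min-1.g-1 in this assay, at which 1 of the 3 values shown sits.

Which part of the new group goes with the fall stays open: the carbonyl, the methyl or the defined stereocentre. Plain pyrrolidin-1-yl or 2-oxopyrrolidin-1-yl at this place would help separate these parts.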